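Hydroxyethyl extension on the shared core: working notes

The source may hold more compounds than are shown below. What is called first, only, known or untested is meant among the compounds shown, and "the series" means these compounds.

Measured so far:
compound 1 `CCCCCCCCN(C)C(=O)Cn1cc(Cc2cnc(=O)n(C)c2)c(=O)nc1SCc1ccc(F)cc1` — 19%
compound 2 `CCCCCCCCCCCCN(C)C(=O)Cn1cc(Cc2cnc(=O)n(C)c2)c(=O)nc1SCc1ccc(F)cc1` — 32%

In a functional assay on a cell-free system (plasma, Oryctolagus cuniculus) for inhibition of platelet-activating factor acetylhydrolase (Homo sapiens), tested at 100 nM (on this read-out lower numbers stand for less inhibition and higher numbers for more inhibition at the one concentration tested (going by the name of the read-out)), compound 1 stands lowest of the two numbers. Its nearest neighbour is compound 2, reached by a number 13 percentage points higher from compound 1 to compound 2 (beyond the scatter), a chain extension far from the site now in question.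

Compound 3 `CCCCCCCCN(C)C(=O)Cn1cc(Cc2cnc(=O)n(CCO)c2)c(=O)nc1SCc1ccc(F)cc1` differs from compound 1 by hydroxymethyl in place of hydrogen on a saturated chain carbon bound to an aromatic nitrogen. Going by the values given here, no measured step touches this site; the one step available, a number 13 percentage points higher from compound 1 to compound 2 (beyond the scatter), concerns the chain on the amide-type nitrogen and gives no guide. The expectation is therefore a step within the scatter, a number 2 percentage points lower from compound 1 to compound 3 (within the scatter), in either direction.

For compound 3 the estimated value in this assay is 17%, expected within 5% to 32%.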

Compound 3, a percentage reported as inhibition, at one concentration (the size of the read-out at that concentration, not a potency): 36%
For compound 3 the middle estimate is 19 percentage points below the measured one, and the stated range ends below it.
By their numbers in this assay, from the lowest: compound 1; then compounds 2 and 3 (each within the scatter of the next).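

The site on the saturated chain carbon bound to an aromatic nitrogen does respond to substitution: methyl to 2-hydroxyethyl gives a number 17 percentage points higher from compound 1 to compound 3 (beyond the scatter) in this assay. Going by these compounds alone, the earlier step concerned only the chain on the amide-type nitrogen, so this is the first reading at this site. Nothing available bears on the origin of this step.

Going by these compounds, whether the step needs the hydroxyl or follows from chain length alone stays open; ethyl and 2-methoxyethyl at this place would separate the two. Also open, on these data alone, is whether the same change holds with the longer amide chain of compound 2.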